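The source may hold more compounds than are shown below. What is called first, only, known or untested is meant among the compounds shown, and "the series" means these compounds.

Measured compounds in a functional assay on A549 cells (Homo sapiens) for cytotoxicity, read by MTT assay; on this read-out lower numbers stand for stronger inhibition and higher numbers for weaker inhibition:
compound 1 `COc1ccc2[nH]c(-c3ccccc3)c(C(c3c(-c4ccccc4)[nH]c4ccc(C)cc34)C3C(=O)NN=C3C)c2c1` gives 1800 nM
compound 2 `CC1=NNC(=O)C1C(c1c(-c2ccccc2)[nH]c2ccccc12)c1c(-c2ccccc2)[nH]c2ccc(C)cc12` gives 22100 nM
compound 3 `COc1ccc2[nH]c(-c3ccccc3)c(C(c3c[nH]c4ccccc34)C3C(=O)NN=C3C)c2c1` gives 2700 nM

Compound 1 and compound 2 differ in one place: hydrogen in place of methoxy on an aromatic carbon. This change brought a 12-fold higher number from compound 1 to compound 2 (1.09 log units; beyond the scatter). Compound 3 stands apart from compound 1 in a larger way; the difference between the two cores is not broken down here. In this assay compound 3 and compound 1 lie within the scatter of each other, whereas compound 2 lies well beyond both.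

Compound 4 `CC1=NNC(=O)C1C(c1c[nH]c2ccccc12)c1c(-c2ccccc2)[nH]c2ccccc12` has not yet been measured. It relates to compound 3 as compound 2 relates to compound 1: hydrogen in place of methoxy on an aromatic carbon. The place lines of the two changes are the same word for word, so this is the same change made on the core of compound 3. Going by the values given here, the step from compound 3 to compound 4 is expected to be of a similar size to the earlier one, a 7.4-fold higher number from compound 3 to compound 4 (0.87 log units; beyond the scatter), resting on the single precedent a 12-fold higher number from compound 1 to compound 2 (1.09 log units; beyond the scatter). Compound 4 is therefore expected near 20000 nM, between 6000 nM and 65000 nM.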

Compound 4, half-maximal inhibitory concentration: 5500 nM
For compound 4 the middle estimate is 3.6-fold (0.56 log units) above the measured one; measured number below the stated range.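

In this assay, hydrogen in place of methoxy weakens inhibition on both cores, but the size of the change does not carry over, with a 2.0-fold higher number from compound 3 to compound 4 (0.31 log units; beyond the scatter) as a modest step set against a large one on the core of compound 1: the same change on two cores in this assay, a 12-fold higher number (1.09 log units; beyond the scatter) from compound 1 to compound 2 and a 2.0-fold higher number (0.31 log units; beyond the scatter) from compound 3 to compound 4, 6.0-fold (0.78 log units) apart, beyond the scatter of two such steps.

The direction therefore holds across both pairs, while its size depends on the core, so a step measured on one core gives a poor guide to the step on the other. The pairs do not show which part of the cores sets the size, since compound 1 and compound 3 differ in more than one place and that difference is not broken down.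

Open, from the compounds shown here alone, is whether a third core would give a step nearer the large or the modest one. Also open, going by these compounds, is how a hydroxyl, an ethoxy, a fluorine or an amine on the same aromatic carbon would compare with methoxy and hydrogen on each core.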